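Amine swap at the chain end of the quinazoline-thiazole amide series

A few compounds are considered here, and "the series" means these few. Any claim that something is new, unique, unknown or untested is made for them only; others in the source may bear on it.

Measured so far:
compound 1: `COc1cc2c(Nc3nc4ccc(C(=O)Nc5c(C)cc(C)cc5C)cc4s3)ncnc2cc1OCCCN1CCC(C)CC1` — 5900 nM
compound 2: `COc1cc2c(Nc3nc4ccc(C(=O)Nc5c(C)cccc5C)cc4s3)ncnc2cc1OCCCN1CCCC1` — 15700 nM

The read-out throughout is a functional assay on K562 cells (Homo sapiens) for cytotoxicity, read by WST assay, with a stated time of 72 h; a lower number here means a stronger inhibitor, a higher number a weaker inhibitor. Of the two numbers in hand, compound 2 holds the higher one; its nearest neighbour, compound 1, sits lower by a gap that is beyond the scatter. The two compounds differ in more than one place, so the pair alone does not say which part of the structure carries that gap.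

Compound 3 is `CCN(CC)CCCOc1cc2ncnc(Nc3nc4ccc(C(=O)Nc5c(C)cccc5C)cc4s3)c2cc1OC`. Set against compound 2, the change is diethylamino in place of pyrrolidin-1-yl on a saturated chain carbon, three bonds along the chain from an oxygen on an aromatic ring. Nothing measured here isolates that change. Both groups carry the same count of heavy atoms and the same acceptor count, so no step beyond the scatter is expected in this assay. For compound 3 the estimate is 13000 nM (range 4500 nM to 38000 nM), which means an expected step of a 1.2-fold lower number from compound 2 to compound 3 (0.08 log units; within the scatter).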

Compound 3, half-maximal inhibitory concentration: 28400 nM
The estimate for compound 3 lay 2.2-fold (0.34 log units) below the measured number; low and high end bracket the measured number.
By their numbers in this assay, from the lowest: compound 1; then compounds 2 and 3 (each within the scatter of the next).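

In this assay, for the compounds shown here, this is the first comparison that differs in one place only, and it gives a 1.8-fold higher number from compound 2 to compound 3 (0.26 log units; within the scatter). Replacing pyrrolidin-1-yl with diethylamino at this chain end opens the ring while keeping the same heavy-atom count, and this step does not separate the two compounds beyond the scatter. Thus, on this amide, the presence or absence of the amine ring has no resolved effect on the read-out. No supporting evidence bears on this result.

Still open, going by these compounds, is whether morpholin-4-yl or dimethylamino in the same place would give a step beyond the scatter. Also unresolved is how much of the gap between compound 1 and compound 2 belongs to the 4-methylpiperidin-1-yl end and how much to the other difference in the structure.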